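Methyl to Methoxy on a Shared Core: Cytotoxicity Outlook

The source may report more compounds than this note shows. Statements on the series, on what has been measured and on what is new or still open speak of the compounds shown alone.

Compound 1, `Cc1ccc(/C=C2\CCC/C(=C\c3ccccc3[N+](=O)[O-])C2=O)cc1`, in an ADME assay on HPC cells (Homo sapiens) for cytotoxicity, with a stated time of 24 h; on this read-out lower numbers stand for higher toxicity in this test and higher numbers for lower toxicity in this test: > 400000 nM, a limit of the assay rather than a number.
Compound 2, `COc1ccc(/C=C2\CCC/C(=C\c3ccccc3[N+](=O)[O-])C2=O)cc1`, in this assay: > 400000 nM, again a limit and not a number.
Compound 3, `Cc1ccc(/C=C2\CCC/C(=C\c3cccc([N+](=O)[O-])c3)C2=O)cc1`, in this assay: 192000 nM.

Of the three measured compounds, only compound 3 gives a number; the other two sit at the same limit, (the limit of > 400000 nM in this assay, at which 2 of the 3 values shown sit). Compound 1 and compound 2 differ in one place: methoxy in place of methyl on an aromatic carbon. Since both values are limits, the step that the two limits leave unreadable from compound 1 to compound 2 cannot be read. Compound 3 shares its atoms with compound 1 but joins them differently; the difference between the two cores is not broken down here.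

Compound 4, `COc1ccc(/C=C2\CCC/C(=C\c3cccc([N+](=O)[O-])c3)C2=O)cc1`, has not yet been measured in this assay. Among the compounds with values here, it differs from compound 3 by methoxy in place of methyl on an aromatic carbon, which is the same change as the one from compound 1 to compound 2, made at the same kind of place. That earlier step gives no usable size because a step that the two limits leave unreadable from compound 1 to compound 2 is hidden by the two limits, so the expectation for compound 4 leans on compound 3 alone, whose value is 192000 nM. The step expected from compound 3 to compound 4 is a 1.0-fold higher number from compound 3 to compound 4 (0.02 log units; within the scatter), close to no change. Compound 4 is therefore estimated at 200000 nM, with a likely range from 80000 nM to 400000 nM, and a fair chance that the assay again reports only a limit.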

Compound 4, half-maximal cytotoxic concentration: 33000 nM
For compound 4 the middle estimate is 6.1-fold (0.78 log units) above the measured one; measured number outside the range, below it.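

In this assay, putting methoxy in place of methyl on the core of the third compound gives a 5.8-fold lower number from compound 3 to compound 4 (0.76 log units; beyond the scatter), so on this core the change from 4-methylphenyl to 4-methoxyphenyl goes with higher toxicity in this test, by a modest step that lies beyond the usual scatter. Within the data shown here, this single pair does not show that the change carries from one core to another: the same swap on the other core has no readable size, so there is no second step to set beside this one, and neither a shared effect nor a core-specific one can be claimed. That other step cannot be read because compound 1 and compound 2 both sit at a limit of the assay rather than at a number: the limit of > 400000 nM in this assay, at which 2 of the 4 values shown sit.

The compounds shown leave open whether a core on which both partners give real numbers would show a step of similar size, or any step at all. They also leave open how other groups at the same place, such as an amine, a carboxylic acid or a longer chain like ethoxy, would compare with methyl and methoxy on either core.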